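A few compounds are considered here, and "the series" means these few. Any claim that something is new, unique, unknown or untested is made for them only; others in the source may bear on it.

Compound 2 `COc1cccc(OC)c1OCCNCCOc1ccccc1OCc1ccccc1[N+](=O)[O-]` was tested in a functional assay on PC-3 cells (Homo sapiens) for cytotoxicity, read by sulforhodamine B assay (on this read-out higher numbers stand for lower toxicity in this test and lower numbers for higher toxicity in this test), where compound 2 gives 95500 nM. Within the data shown here, its only measured relative is compound 1 `COc1cccc(OC)c1OCCNCCOc1ccccc1OCc1cccc(Cl)c1`, which in this assay gives 58900 nM; the two are separated by a 1.6-fold higher number from compound 1 to compound 2 (0.21 log units; within the scatter). Compound 3 `COc1ccccc1COc1ccccc1OCCNCCOc1c(OC)cccc1OC` differs from compound 2 by methoxy in place of nitro on an aromatic carbon. Among the measured compounds shown here, the one step measured so far also exchanged the group at this end of the molecule and stayed within the scatter, so the present exchange is expected to give a 1.2-fold lower number from compound 2 to compound 3 (0.08 log units; within the scatter). Compound 3 is therefore estimated at 80000 nM, with a range from 35000 nM to 180000 nM.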

Compound 3, concentration lethal to 50% of the cells: 100000 nM
Estimate against measurement, compound 3: 1.3-fold (0.10 log units) below, within the range that was stated.
By their numbers in this assay, from the lowest: compounds 1, 2 and 3 (each within the scatter of the next).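

In this assay the exchange of nitro for methoxy on this aromatic carbon, a change of this one group alone, gives a 1.0-fold higher number from compound 2 to compound 3 (0.02 log units; within the scatter) and so shows that the two groups cannot be told apart here. The comparison with the 3-chlorophenyl end gives a 1.7-fold higher number from compound 1 to compound 3 (0.23 log units; within the scatter) and so adds a third end group that cannot be told apart from the other two in this test. No measurement on hand explains this result.

On these data alone, whether an amine or a carboxylic acid on this aromatic carbon would also stay within the scatter remains open. So does whether methoxy and nitro would read alike elsewhere on this ring.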